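The source may hold more compounds than are shown below. What is called first, only, known or untested is meant among the compounds shown, and "the series" means these compounds.

Three compounds of this study have a measured number or a limit in a functional assay on MCF7 cells (Homo sapiens) for inhibition, read by MTT assay, with a stated time of 72 h; a lower number here means a stronger inhibitor, a higher number a weaker inhibitor. Compound 1 `Cc1ccc(S(=O)(=O)Nc2cc[nH]c(=O)n2)cc1` gives 27000 nM. Compound 2 `O=c1nc(NO)cc[nH]1` reaches only a limit, > 100000 nM. Compound 3 `NCC(=O)Nc1c[nH]c(=O)[nH]c1=O` likewise reaches only a limit, > 100000 nM. So compound 3 stands at a limit and not at a number, and it shares that place with compound 2, as the limit of > 100000 nM in this assay, at which 2 of the 3 values shown sit, records. For the measured compounds named here, the only value within range of measurement is that of compound 1.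

Compound 4 `O=C(CCl)Nc1c[nH]c(=O)[nH]c1=O` is not yet measured. It differs from compound 3 by a single change: chloro in place of amino on a saturated chain carbon bound to a carbonyl carbon. Going by the values given here, no step between two measured compounds of this set is known, so nothing measured shows how large such a change turns out in this assay. The step from compound 3 to compound 4 is expected to be an at least 1.6-fold lower number from compound 3 to compound 4 (0.22 log units; that floor lies within the scatter), a gain in potency that would exceed the usual scatter if it appears, though an outcome again at a limit remains quite possible. Compound 4 is estimated at 60000 nM, within a range from 15000 nM to 200000 nM.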

Compound 4, half-maximal inhibitory concentration: 15000 nM
For compound 4 the middle estimate is 4.0-fold (0.60 log units) above the measured one; low and high end bracket the measured number.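

In this assay, for the compounds shown here, the exchange of aminomethyl for chloromethyl gives the first measured step of this set, an at least 6.6-fold lower number from compound 3 to compound 4 (0.82 log units; beyond the scatter). The earlier compounds shown here could not show this, as no two of them differed in one place; now a change of one heavy atom, on a saturated chain carbon bound to a carbonyl carbon, is seen to move a compound from a limit to a number. Compound 3 holds a limit and not a number, so the step gives only a floor for the size of the change: the limit of > 100000 nM in this assay, at which 2 of the 4 values shown sit.

The compounds shown leave open whether the gain is particular to chloro or would also appear with bromo, a hydroxyl or a longer chain in this place. They also leave open whether the same exchange would count on the core of compound 1.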